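A Longer Side Chain on Two Related Cores

The source may hold more compounds than are shown below. What is called first, only, known or untested is meant among the compounds shown, and "the series" means these compounds.

Four compounds share a sulfonamide built on a ring-bound chain and differ in the chain and in the ring. Compound 1 `Cc1ccc(S(=O)(=O)N2CC[C@@H](Cl)C[C@@H]2CC(C)C)cc1` and compound 2 `CCCCCCC[C@H]1C[C@H](Cl)CCN1S(=O)(=O)c1ccc(C)cc1` have a saturated ring; compound 3 `Cc1ccc(S(=O)(=O)N2CCC(Cl)=CC2CC(C)C)cc1` and compound 4 `CCCCCCCC1C=C(Cl)CCN1S(=O)(=O)c1ccc(C)cc1` carry a double bond in that ring. The difference between the two cores is not broken down here.

All were, or are to be, tested in a functional assay on WiDr cells (Homo sapiens) for antiproliferative activity, read by sulforhodamine B assay, with a stated time of 48 h; on this read-out lower numbers stand for stronger inhibition of growth and higher numbers for weaker inhibition of growth. Compound 1 gives 22000 nM, compound 2 gives 54000 nM, and compound 3 gives 21000 nM. Compound 1 and compound 3 are within the usual scatter of each other, so no order between them can be read.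

The change from compound 1 to compound 2 is hexyl in place of isopropyl on a saturated chain carbon bound to a saturated ring carbon. This change made a 2.5-fold higher number from compound 1 to compound 2 (0.39 log units; beyond the scatter), a modest weakening of growth inhibition. The same change is now applied to the second core: compound 4 differs from compound 3 by hexyl in place of isopropyl on a saturated chain carbon bound to a saturated ring carbon, at the same place.

For the measured compounds named here, for compound 4 the step is expected to be a 2.4-fold higher number from compound 3 to compound 4 (0.38 log units; beyond the scatter), resting on the single earlier example, since the same chain lengthening weakened inhibition in a 2.5-fold higher number from compound 1 to compound 2 (0.39 log units; beyond the scatter) on the saturated core. Going by the values given here, compound 4 is therefore estimated to give 50000 nM, with the plausible range running from 22000 nM to 110000 nM; with only one precedent the step could differ on the new core.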

Compound 4, concentration for 50% growth inhibition: 50000 nM
Compound 4: the middle estimate sits on the measured number at the digits printed; low and high end bracket the measured number.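

In this assay, replacing isopropyl with hexyl on the core with the double bond gave a 2.4-fold higher number from compound 3 to compound 4 (0.38 log units; beyond the scatter), a modest weakening of growth inhibition. Set beside the same replacement on the saturated core, the step keeps its direction and its size, so in these two pairs the effect of the change did not depend on which of the two cores carried it: the same change on two cores in this assay, a 2.5-fold higher number (0.39 log units; beyond the scatter) from compound 1 to compound 2 and a 2.4-fold higher number (0.38 log units; beyond the scatter) from compound 3 to compound 4, 1.0-fold (0.01 log units) apart, within the scatter of two such steps

For the compounds shown here, this agreement rests on only two pairs, a single replacement and a single cell line, so it does not show that the step would carry over to other cores or to other chains, and it gives no explanation of why growth inhibition weakens when the chain changes in this way.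

The compounds shown offer only isopropyl and hexyl at this place, which leaves open how the number would move with an ethyl group, with a chain of intermediate length or a still longer one, or with a chain ending in an amine or a carboxylic acid. On these data alone, it also remains open whether the step would stay the same if the chloro group on the ring gave way to another group, such as fluoro or methoxy.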